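A few compounds are considered here, and "the series" means these few. Any claim that something is new, unique, unknown or untested is made for them only; others in the source may bear on it.

Values in a functional assay on MCF7 cells (Homo sapiens) for inhibition, read by MTT assay, with a stated time of 5 days (on this read-out higher numbers stand for weaker inhibition and lower numbers for stronger inhibition), for the compounds measured so far

Compound 1 `Cc1cc(Nc2nc(NCc3ccccc3Br)nc3[nH]ncc23)n[nH]1` gives 14100 nM
Compound 2 `Cc1cc(Nc2nc(NCc3ccc(F)cc3)nc3[nH]ncc23)n[nH]1` gives 970 nM
Compound 3 `Cc1cc(Nc2nc(NCc3ccc(Br)cc3)nc3[nH]ncc23)n[nH]1` gives 5340 nM

Among these three, compound 3 at 5340 nM sits in the middle, with compound 1 at a higher number and compound 2 at a lower one. Still unmeasured is compound 4 `Cc1cc(Nc2nc(NCc3ccc(F)cc3F)nc3[nH]ncc23)n[nH]1`, which differs from compound 3 in one place: 2,4-difluorophenyl in place of 4-bromophenyl on a saturated chain carbon bound to a nitrogen on an aromatic ring, with 2,4-difluorophenyl in place of 4-bromophenyl on a saturated chain carbon bound to a nitrogen on an aromatic ring.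

The closest evidence is a 5.5-fold higher number from compound 2 to compound 3 (0.74 log units; beyond the scatter), a modest step that came with bromo in place of fluoro on an aromatic carbon. Compound 4 reverses that exchange, which points towards a lower number. The other two steps, a 2.6-fold lower number from compound 1 to compound 3 (0.42 log units; beyond the scatter) and a 15-fold lower number from compound 1 to compound 2 (1.16 log units; beyond the scatter), both start from the 2-bromophenyl group, and that group has the highest number of the three. Among the compounds with values here, no measured compound carries a second fluoro, so part of the drop may fail to appear. The expected change is a 3.3-fold lower number from compound 3 to compound 4 (0.52 log units; beyond the scatter), a modest step towards stronger inhibition. For compound 4 the estimated value is 1600 nM, with an expected range from 500 nM to 5000 nM.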

Compound 4, half-maximal inhibitory concentration: 670 nM
Compound 4: middle estimate off by 2.4-fold (0.38 log units), on the high side; the measured number falls inside the stated range.
By their numbers in this assay, from the lowest: compounds 4 and 2 (each within the scatter of the next); then compound 3; then compound 1.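

In this assay, a second fluoro on the ring makes no difference that can be told apart from the scatter (a 1.4-fold lower number from compound 2 to compound 4 (0.16 log units; within the scatter)), so 2,4-difluorophenyl and 4-fluorophenyl read alike on a saturated chain carbon bound to a nitrogen on an aromatic ring. The distance from the bromo compounds now rests on two fluoro compounds rather than one, with one step running from the 4-bromophenyl group (an 8.0-fold lower number from compound 3 to compound 4 (0.90 log units; beyond the scatter)) and a larger one from the 2-bromophenyl group (a 21-fold lower number from compound 1 to compound 4 (1.32 log units; beyond the scatter)); among these four compounds, both fluoro compounds give lower numbers than both bromo compounds, and none goes against this. No measurement shown here explains why changing from bromo to fluoro lowers the number in these compounds.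

The compounds shown leave open how chloro, methoxy, an amine or a carboxylic acid on this ring would compare with fluoro and bromo, and what a longer chain in this place would do. From the compounds shown here alone, it also remains open whether the same order of the four compounds would appear in cells other than these.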